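Aryl substituent swap in a hydroxamic acid series

A few compounds are considered here, and "the series" means these few. Any claim that something is new, unique, unknown or untested is made for them only; others in the source may bear on it.

Compound 1 `O=C(CCC1=CCN(CCCc2ccc(Cl)cc2)C1=O)NO` and compound 2 `CCOc1ccc(CCCN2CC=C(CCC(=O)NO)C2=O)cc1` share the same core and differ only in the group carried on the aromatic ring. In a functional assay on ACHN cells (Homo sapiens) for inhibition, read by sulforhodamine B assay (on this read-out higher numbers stand for weaker inhibition of growth and lower numbers for stronger inhibition of growth), compound 1 gives 3330 nM. In this assay compound 2 gives 3330 nM. For the measured compounds named here, the one measured step, no change at the digits printed from compound 1 to compound 2 (within the scatter), shows that this substituent swap left growth inhibition where it was. Compound 1 therefore stands level with compound 2 on the numbers to hand, and neither can be called the stronger of the pair.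

Compound 3 `Cc1cccc(CCCN2CC=C(CCC(=O)NO)C2=O)c1` is not yet measured. It differs from compound 1 by 3-methylphenyl in place of 4-chlorophenyl on a saturated chain carbon, three bonds along the chain from an amide-type nitrogen in a ring. Going by the values given here, the only step that bears on this change is no change at the digits printed from compound 1 to compound 2 (within the scatter), a swap of substituent on the same aromatic ring that produced no shift beyond the scatter. On that single precedent no shift beyond the scatter is expected for the move to compound 3 either, and the expected step of a 1.0-fold lower number from compound 1 to compound 3 (0.00 log units; within the scatter) is set close to zero. Among the compounds with values here, compound 3 is thus expected to give 3300 nM in this assay, with a range from 1500 nM to 7500 nM that reflects how thin the precedent is, since a methyl-bearing ring has no measured counterpart.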

Compound 3, concentration for 50% growth inhibition: 3330 nM
The estimate for compound 3 lay 1.0-fold (0.00 log units) below the measured number; measured number inside the range.
By their numbers in this assay, from the lowest: compounds 1, 2 and 3 (each within the scatter of the next).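

In this assay, replacing 4-chlorophenyl with 3-methylphenyl on a saturated chain carbon, three bonds along the chain from an amide-type nitrogen in a ring, gives no change at the digits printed from compound 1 to compound 3 (within the scatter). Compound 2 differed from compound 1 only in the group on an aromatic carbon, whereas here the names 4-chlorophenyl and 3-methylphenyl show a different group at a different numbered ring place, and the reading again falls within the scatter. The three compounds therefore tolerate both kinds of swap in this assay, although no data on any property of these groups are available to account for the result.

The compounds shown all carry a neutral group on the aromatic ring, so it remains open whether a carboxylic acid or a dimethylamino group there would give a reading beyond the scatter. The chain holding the ring is also the same throughout, which leaves open whether a longer chain or a pyridine ring in place of the phenyl ring would read differently in this assay.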